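A Difluorophenyl Sulfonamide Measured Against Three Limits

The source may hold more compounds than are shown below. What is called first, only, known or untested is meant among the compounds shown, and "the series" means these compounds.

Measured compounds:
compound 1 `CC1CCN(C2CCN(S(=O)(=O)c3cccnc3Cl)CC2)CC1` — > 5000 nM
compound 2 `CC1CCN(C2CCN(S(=O)(=O)c3nccn3C)CC2)CC1` — > 5000 nM
compound 3 `CC1CCN(C2CCN(S(=O)(=O)c3cncc(Br)c3)CC2)CC1` — > 5000 nM

In a functional assay on DLD-1 cells (Homo sapiens) for antiproliferative activity, read by CellTiter-Glo, with a stated time of 72 h (on this read-out lower numbers stand for stronger inhibition and higher numbers for weaker inhibition), compound 3 gives > 5000 nM, which is a limit of the assay and not a number; compounds 1 and 2 likewise reach only that limit. Compound 3 therefore stands at the limit of > 5000 nM in this assay, at which 3 of the 3 values shown sit, with no number of its own. Compound 4 `CC1CCN(C2CCN(S(=O)(=O)c3ccc(F)cc3F)CC2)CC1` differs from it by 2,4-difluorophenyl in place of 5-bromopyridin-3-yl on a sulfonyl sulfur. The measured steps that reach compound 3 are a step that the two limits leave unreadable from compound 1 to compound 3 and a step that the two limits leave unreadable from compound 2 to compound 3. Neither has a readable size, so no direction can be drawn for exchanging the aromatic ring on the sulfonyl sulfur in this assay. Compound 4 is expected to show a step that the limit leaves unreadable from compound 3 to compound 4 and an estimated value of 6000 nM, between 1500 nM and 20000 nM.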

Compound 4, half-maximal inhibitory concentration: 102 nM
Estimate against measurement, compound 4: 59-fold (1.77 log units) above, outside the stated range (below it).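

In this assay, the ring on the sulfonyl sulfur now proves to matter, as 2,4-difluorophenyl gives an at least 49-fold lower number from compound 3 to compound 4 (1.69 log units; beyond the scatter), an at least 49-fold lower number from compound 2 to compound 4 (1.69 log units; beyond the scatter) and an at least 49-fold lower number from compound 1 to compound 4 (1.69 log units; beyond the scatter). Each of these steps starts from a limit rather than a number, and the steps among the earlier compounds cannot be read: the limit of > 5000 nM in this assay, at which 3 of the 4 values shown sit.

As far as these compounds go, what a plain phenyl ring on the sulfonyl sulfur would give remains open. The compounds shown therefore cannot separate the contribution of the two fluorine atoms from that of a ring of carbon only.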